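This account rests on a few compounds, and the source may have more. Where it says the series, first, only, none or still open, it means among the compounds named here.

Measured so far:
compound 1, `O=C1c2c[n+]([O-])c3ccccc3c2C(=O)c2c1c1ccccc1n2Cc1cn([C@H]2O[C@H](CO)[C@@H](O)[C@H]2O)nn1`, in a toxicity assay on L02 cells (Homo sapiens) for cytotoxicity, read by MTT assay, with a stated time of 72 h (a lower number here means a stronger inhibitor, a higher number a weaker inhibitor), gives 950 nM;
compound 2, `O=C1c2c[n+]([O-])c3ccccc3c2C(=O)c2c1c1ccccc1n2CCCCn1ccnc1`, in this assay gives 150 nM;
compound 3, `O=C1c2c[n+]([O-])c3ccccc3c2C(=O)c2c1c1ccccc1n2Cc1cn([C@@H]2C[C@H](O)[C@@H](CO)O2)nn1`, in this assay gives 630 nM.

Compound 3 stands second highest of the three numbers in this assay. Its nearest neighbour is compound 1, whose value lies within the scatter of it, and its furthest is compound 2, whose value lies beyond the scatter and is the lower of the two.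

Compound 4, `O=C1c2c[n+]([O-])c3ccccc3c2C(=O)c2c1c1ccccc1n2Cc1cn(C[C@H](O)CO)nn1`, has not yet been measured. It differs from compound 3 at one place: 2,3-dihydroxypropyl in place of 4-hydroxy-5-(hydroxymethyl)oxolan-2-yl on an aromatic nitrogen. Going by the values given here, the only step so far that touches the same part of the molecule is the one from compound 1 to compound 3, which changed a hydroxy to hydrogen on a saturated ring carbon and gave a 1.5-fold lower number from compound 1 to compound 3 (0.18 log units; within the scatter). That step tells that altering the hydroxylated group on the aromatic nitrogen did not move the number beyond the scatter. Among the compounds with values here, compound 2 carries a quite different group at this nitrogen and gives a lower number, but no single step connects it to compound 3, so it only hints that larger changes here can matter.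

On this basis compound 4 is expected to show a 1.1-fold lower number from compound 3 to compound 4 (0.02 log units; within the scatter), a step within the scatter. The estimate for compound 4 in this assay is 600 nM, with a range from 250 nM to 1500 nM.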

Compound 4, half-maximal inhibitory concentration: 1130 nM
Estimate against measurement, compound 4: 1.9-fold (0.27 log units) below; the range from low to high includes it.
By their numbers in this assay, from the lowest: compound 2; then compounds 3, 1 and 4 (each within the scatter of the next).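

In this assay the ring-free 2,3-dihydroxypropyl in place of 4-hydroxy-5-(hydroxymethyl)oxolan-2-yl gives a 1.8-fold higher number from compound 3 to compound 4 (0.25 log units; within the scatter) and, set against the 3,4-dihydroxy-5-(hydroxymethyl)oxolan-2-yl group, gives a 1.2-fold higher number from compound 1 to compound 4 (0.08 log units; within the scatter) as well, so on this aromatic nitrogen the five-membered non-aromatic ring and its defined stereocentres can be given up without the number leaving the scatter. Going by these compounds alone, a direct step also shows for the first time that a change in this part of the molecule can move the number beyond the scatter: 1-(2,3-dihydroxypropyl)-1H-1,2,3-triazol-4-yl in place of 3-(1H-imidazol-1-yl)propyl gives a 7.5-fold higher number from compound 2 to compound 4 (0.88 log units; beyond the scatter) and thus separates the imidazole-bearing chain from the open diol. Nothing measured here gives a reason for any of these numbers.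

On these data alone, that last step replaces the whole side chain at once, so it stays open which part of the chain goes with the lower number of compound 2. As far as these compounds go, also open in this assay is how an amine or a carboxylic acid in place of the hydroxy groups of 2,3-dihydroxypropyl would read.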